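A few compounds are considered here, and "the series" means these few. Any claim that something is new, unique, unknown or untested is made for them only; others in the source may bear on it.

Among the compounds with values here, in a functional assay on HepG2 cells (Homo sapiens) for antiproliferative activity, read by XTT assay, with a stated time of 72 h (a lower number here means a stronger inhibitor, a higher number a weaker inhibitor), the three compounds measured so far stand as follows.

Compound 1, `COc1ncnc2c1c(I)cn2[C@@H]1O[C@H](CO)[C@@H](O)[C@H]1O`, gives > 20000 nM, which is a limit of the assay rather than a number.
Compound 2, `COc1nc(N)nc2c1c(-c1ccccc1)cn2[C@@H]1O[C@H](CO)[C@@H](O)[C@H]1O`, gives > 20000 nM, again a limit.
Compound 3, `COc1ncnc2c1c(-c1ccccc1)cn2[C@@H]1O[C@H](CO)[C@@H](O)[C@H]1O`, gives > 20000 nM, also a limit.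

So compound 3 stands nowhere that can be placed: its value is a limit, and the two other values shown are limits as well. The two one-place steps that lead to compound 3 tell nothing about size because of the limit of > 20000 nM in this assay, at which 3 of the 3 values shown sit. The step that the two limits leave unreadable from compound 1 to compound 3 and the step that the two limits leave unreadable from compound 2 to compound 3 both remain unreadable for that reason.

Compound 4, `COc1ncnc2c1c(-c1cc3ccccc3o1)cn2[C@@H]1O[C@H](CO)[C@@H](O)[C@H]1O`, differs from compound 3 in one place: 1-benzofuran-2-yl in place of phenyl on an aromatic carbon. Neither measured step bears on this change, as both are unreadable, so there is no basis in these data for expecting a step in this assay in either direction. The most that can be expected is that compound 4 will behave much as compound 3 does, and the step that the limit leaves unreadable from compound 3 to compound 4 is estimated to be essentially none. Compound 4 is therefore estimated at 25000 nM, within a range from 5000 nM to 100000 nM, with a considerable chance that only a limit is reported.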

Compound 4, half-maximal inhibitory concentration: > 20000 nM
Compound 4 ended at the assay's limit; the forecaster's own chance of this, stated with the estimate: 75%; the middle value is on the limit's open side.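

In this assay compound 4 gives > 20000 nM, which is a limit of the assay and not a number. No size can be read for the steps to compound 4 from compound 3 or from compound 1, because all the values share one limit: the limit of > 20000 nM in this assay, at which 4 of the 4 values shown sit.

The compounds shown leave open whether any change to the shared core would give a readable value in this assay.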